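This account rests on a few compounds, and the source may have more. Where it says the series, first, only, none or still open, it means among the compounds named here.

Measured in a functional assay on Bel-7402 cells (Homo sapiens) for inhibition, read by MTT assay, with a stated time of 24 h, tested at 0.1 ug/mL; a lower number here means less inhibition of growth, a higher number more inhibition of growth at the concentration tested:

- compound 1 (`O=C(CCCCC(S)CCS)NO`) reads (5.96%)
- compound 2 (`O=C(CCCCC1CCSS1)Nc1cccc2ccccc12`) reads (3.4%)
- compound 3 (`O=C(CCCCC(S)CCS)Nc1ccc(F)cc1`) reads ("not active" (no number reported))

Compound 3 has no number to stand on, only the verdict ("not active" (no number reported)). Compound 1 and compound 2 lie within the scatter of each other, and both readings are small. Compound 4 (`O=C(CCCCC(S)CCS)Nc1ccc([N+](=O)[O-])cc1`) is the untested structure. The change (nitro in place of fluoro on an aromatic carbon) puts nitro in place of fluoro on an aromatic carbon, para to a large group. Within the data shown here, no measured pair shows what this swap does, so no step beyond the scatter is expected in this assay, and no direction can be given. Compound 4 is expected to read about 5% (estimated range 0% to 15%).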

Compound 4, percent growth inhibition at one concentration: 1.88%
For compound 4 the middle estimate is 3.1 percentage points above the measured one, within the range that was stated.
By their numbers in this assay, from the lowest: compounds 4, 2 and 1 (each within the scatter of the next).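

Compound 3 carries only the verdict "not active" (no number reported) and compound 4 reads 1.88%, so no step can be read between them. Going by these compounds, what nitro in place of fluoro does in this assay stays open, and no supporting evidence is available here.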